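The source may report more compounds than this note shows. Statements on the series, on what has been measured and on what is new or still open speak of the compounds shown alone.

Measured compounds:
- Compound 1, `O=S(=O)(CC1=NCCS1)C1C(c2ccccc2)=NOC1c1ccccc1`, in a functional assay, read by Griess assay, with a stated time of 150 min, tested at 50 ug/mL; on this read-out higher numbers stand for a stronger effect at the one concentration tested and lower numbers for a weaker effect: compound 1 gives "not active" (no number reported).
- Compound 2, `COc1ccc(-c2nn(-c3ccccc3)c(-c3ccc(C)cc3)c2S(=O)(=O)CC2=NCCO2)cc1`: compound 2 gives 61.6%.
- Compound 3, `O=S(=O)(CC1=NCCS1)c1c(-c2ccccc2)nn(-c2ccccc2)c1-c1ccccc1`: compound 3 gives "not active" (no number reported).

Compound 1 stands without a single number in this assay; it is reported only as not active, and compound 3 shares that status, so no ordering among these two can be drawn. Compound 2 is the only one of the three with a number, and it carries the oxazoline-type ring on a different core, so its value cannot be tied by a single step to compound 1 or compound 3.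

Compound 4, `O=S(=O)(CC1=NCCO1)C1C(c2ccccc2)=NOC1c1ccccc1`, is not yet measured. It differs from compound 1 as follows: a group of 5 heavy atoms (3 carbon, 1 nitrogen, 1 oxygen; one five-membered non-aromatic ring with 2 hetero atoms) in place of a group of 5 heavy atoms (3 carbon, 1 nitrogen, 1 sulfur; one five-membered non-aromatic ring with 2 hetero atoms), on a saturated chain carbon bound to a sulfonyl sulfur. Within the data shown here, no measured pair isolates this exchange, so the size of the step is open. Compound 2, the only active entry, carries the entering group, while both entries with the leaving group are not active; this is suggestive but confounded by the different cores. Compound 4 is therefore expected to show a weak to modest effect, estimated at 25% with a range from 0% to 55%, and a fair chance that it too is reported only as not active.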

Compound 4, a percentage reported as activity, at one concentration (the size of the read-out at that concentration, not a potency): 53.9%
Estimate against measurement, compound 4: 28.9 percentage points below, and the stated range covers the measured number.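

In this assay, among these compounds, compound 4 gives 53.9% while compound 1 gives "not active" (no number reported) and so no step between them can be read. The compounds shown leave open how large this ring exchange is on any core. Nothing shown offers an explanation for the result.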